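The source may hold more compounds than are shown below. What is called first, only, known or untested is meant among the compounds shown, and "the series" means these compounds.

Measured compounds:
- Compound 1, `NC(=O)Nc1sc(-c2ccccc2)cc1C(=O)Nc1ccccc1`: in a functional assay on HT-29 cells (Homo sapiens) (on this read-out lower numbers stand for an effect already at smaller amounts and higher numbers for an effect only at larger amounts of compound), compound 1 has the entry "not determined" (no result reported), so no result was reported.
- Compound 2, `CN(C)c1ccc(-c2cc(C(=O)N[C@H]3CCCNC3)c(NC(N)=O)s2)cc1`: in this assay compound 2 gives 90 nM.

Going by the values given here, compound 2 therefore stands as the only compound with a number in this assay; compound 1 carries no value, so nothing can be compared between the two, and no step between measured compounds is available as a guide.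

Compound 3, `CS(=O)(=O)c1ccc(-c2cc(C(=O)N[C@H]3CCCNC3)c(NC(N)=O)s2)cc1`, is the next compound to be tested. It differs from compound 2 in a single place: methylsulfonyl in place of dimethylamino on an aromatic carbon. Among the compounds with values here, since no measured step of this kind exists here, the size and direction of the change must be guessed. A shift in this assay of a modest size, leaning toward a higher number, seems plausible, though a result within the scatter of compound 2 cannot be ruled out. For compound 3 the expected value in this assay is 250 nM, with a likely range from 60 nM to 1200 nM, which corresponds to an estimated step of a 2.8-fold higher number from compound 2 to compound 3 (0.44 log units; beyond the scatter).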

Compound 3, half-maximal effective concentration: 200 nM
Estimate against measurement, compound 3: 1.3-fold (0.10 log units) above, and the stated range covers the measured number.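

In this assay, putting methylsulfonyl in place of dimethylamino on the aromatic carbon gives a 2.2-fold higher number from compound 2 to compound 3 (0.35 log units; beyond the scatter). Going by these compounds alone, this is the first measured look at this position, and it shows that the number responds to the group placed there. Even so, exchanging a group of carbon and nitrogen atoms for one of carbon, sulfur and oxygen moves the number by only a modest step. Nothing available explains why the number moves in this direction.

A single step gives two points and no trend, so it cannot show how other groups at this position would behave. On these data alone, whether a methoxy group, a fluorine atom or a carboxylic acid in the same place would give a lower or a higher number remains open.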